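Notes on the step from compound 2 to compound 4

A few compounds are considered here, and "the series" means these few. Any claim that something is new, unique, unknown or untested is made for them only; others in the source may bear on it.

For the measured compounds named here, compound 2 `Cc1ccc(N(C(=O)c2ccccc2C)C(=S)OCCN2C(=O)c3ccccc3C2=O)cc1` is the one member for which an ADME assay on MT4 cells (Homo sapiens) for cytotoxicity, read by MTT assay (on this read-out higher numbers stand for lower toxicity in this test and lower numbers for higher toxicity in this test), reports only a limit, > 100000 nM. Compound 1 `Cc1ccccc1C(=O)N(C(=S)OCCN1C(=O)c2ccccc2C1=O)c1ccc(Cl)cc1` gives 21000 nM in this assay, and compound 3 `O=C1c2ccccc2C(=O)N1CCOC(=S)N(C(=O)c1ccc(Cl)c(Cl)c1)c1ccccc1` gives 52000 nM. Going by the values given here, the single measured step, an at least 4.7-fold higher number from compound 1 to compound 2 (0.67 log units; beyond the scatter), replaces a chloro by a methyl, and its size is known only up to the limit of > 100000 nM in this assay, at which 1 of the 3 values shown sits. Compound 4 `Cc1ccc(N(C(=O)c2ccc(Cl)cc2Cl)C(=S)OCCN2C(=O)c3ccccc3C2=O)cc1` differs from compound 2 by 2,4-dichlorophenyl in place of 2-methylphenyl on a carbonyl carbon, an exchange in the opposite sense, though on a different ring, so a number somewhat below the limit is expected rather than assured. The expectation for compound 4 is 60000 nM, between 25000 nM and 150000 nM, which is an expected step of an at least 1.6-fold lower number from compound 2 to compound 4 (0.22 log units; that floor lies within the scatter).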

Compound 4, half-maximal cytotoxic concentration: 49000 nM
For compound 4 the middle estimate is 1.2-fold (0.09 log units) above the measured one; low and high end bracket the measured number.
By their numbers in this assay, from the lowest: compound 1; then compounds 4 and 3 (each within the scatter of the next). At a limit, above all of these: compound 2.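

This is the first change shown on the carbonyl carbon, and in this assay it gives an at least 2.0-fold lower number from compound 2 to compound 4 (0.30 log units; that floor lies within the scatter). With that floor inside the scatter, this pair alone establishes no real drop in the number. Compound 2 remains a limit, so the step has a floor but no known size: the limit of > 100000 nM in this assay, at which 1 of the 4 values shown sits. Still open, going by these compounds, is whether a single chloro on this ring gives a similar reading. Also open, on these data alone, is how an amine or a carboxylic acid on this ring, or a longer alkyl chain in its place, would read.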